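This account rests on a few compounds, and the source may have more. Where it says the series, first, only, none or still open, it means among the compounds named here.

Measured in a functional assay on HepG2 cells (Homo sapiens) for antiproliferative activity, read by MTT assay, with a stated time of 72 h; on this read-out lower numbers stand for stronger inhibition and higher numbers for weaker inhibition:
- compound 1 `O=C(N/N=C/c1cccc(Br)c1)Nc1ccc(Oc2ccnc3[nH]ccc23)c(F)c1`: 660 nM
- compound 2 `O=C(N/N=C/c1ccc([N+](=O)[O-])cc1)Nc1ccc(Oc2ccnc3[nH]ccc23)c(F)c1`: 3030 nM

Of these two, compound 2 has the higher number, 3030 nM, and compound 1 gives 660 nM. The next compound to be tested in this assay is compound 3 `O=C(N/N=C/c1cccc(Cl)c1Cl)Nc1ccc(Oc2ccnc3[nH]ccc23)c(F)c1`, which keeps the core of compound 2 and changes one group: 2,3-dichlorophenyl in place of 4-nitrophenyl on a carbon with a double bond to nitrogen. In short, 2,3-dichlorophenyl replaces 4-nitrophenyl on a carbon with a double bond to nitrogen.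

Going by the values given here, only one measured step bears on this: a 4.6-fold higher number from compound 1 to compound 2 (0.66 log units; beyond the scatter), a modest change that lies beyond the scatter and also involves 4-nitrophenyl at this place. No 2,3-dichlorophenyl compound has been measured, so the reasoning rests on compound 1, a halogen-bearing phenyl compound, alone. A modest move to a lower number is expected, smaller than that single step. The estimated change is a 3.0-fold lower number from compound 2 to compound 3 (0.48 log units; beyond the scatter). For compound 3 the estimated value is 1000 nM, with an expected range of 330 nM to 3000 nM.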

Compound 3, half-maximal inhibitory concentration: "not active" (no number reported)
The entry for compound 3 holds no number; no gap can be computed for the estimate.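

In this assay, going by these compounds alone, compound 3 is entered as not active, without a number; no step from compound 2 to compound 3 can be read. No supporting data bear on this result. The compounds shown leave open where compound 3 stands numerically against compound 1 and compound 2.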